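This account rests on a few compounds, and the source may have more. Where it says the series, first, only, none or still open, it means among the compounds named here.

Measured so far in a functional assay on SNB-19 cells (Homo sapiens) for inhibition, read by sulforhodamine B assay, with a stated time of 48 h, tested at 10 uM; on this read-out lower numbers stand for less inhibition and higher numbers for more inhibition at the one concentration tested (going by the name of the read-out):
- compound 1 `c1ccc(-c2cn3ccnc3c(-c3ccc4ncn(C5CCCCC5)c4c3)n2)cc1`: 22.9%
- compound 2 `Brc1ccc(-c2cn3ccnc3c(-c3ccc4ncn(C5CCCCC5)c4c3)n2)cc1`: 18.3%

Compound 2 is the lower of the two numbers, but the step of a number 4.6 percentage points lower from compound 1 to compound 2 (within the scatter) lies within the scatter, so compound 2 does not separate from compound 1 in this assay.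

Compound 3 `FC(F)(F)c1cccc(-c2cn3ccnc3c(-c3ccc4ncn(C5CCCCC5)c4c3)n2)c1` differs from compound 2 by 3-(trifluoromethyl)phenyl in place of 4-bromophenyl on an aromatic carbon. Among the measured compounds shown here, the only measured step that bears on this change is the one from compound 1 to compound 2, which exchanged a substituent on the same six-membered ring of carbon only and produced a number 4.6 percentage points lower from compound 1 to compound 2 (within the scatter), a step within the scatter. For the measured compounds named here, nothing measured here shows that substituents on that ring move the read-out beyond the scatter, and no step for a trifluoromethyl group exists. The step of a number 1.7 percentage points higher from compound 2 to compound 3 (within the scatter) is therefore expected to stay within the scatter, in no fixed direction. Compound 3 is estimated at 20%, with a range from 8% to 32%.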

Compound 3, a percentage reported as inhibition, at one concentration (the size of the read-out at that concentration, not a potency): 2.24%
For compound 3 the middle estimate is 17.8 percentage points above the measured one, and the stated range ends above it.
By their numbers in this assay, from the lowest: compound 3; then compounds 2 and 1 (each within the scatter of the next).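

In this assay, the phenyl ring on the shared core is not a silent place after all: the change gives a number 16.1 percentage points lower from compound 2 to compound 3 (beyond the scatter) and, against the unsubstituted ring, a number 20.7 percentage points lower from compound 1 to compound 3 (beyond the scatter), whereas bromo left the read-out within the scatter, with a number 4.6 percentage points lower from compound 1 to compound 2 (within the scatter). Trifluoromethyl in place of hydrogen is thus the first single change in this series to take the number beyond the scatter, and it does so downward, towards less inhibition. Nothing available explains this step.

The compounds shown do not separate the trifluoromethyl group itself from the place it holds, since 3-(trifluoromethyl)phenyl differs from 4-bromophenyl in both. On these data alone, it also stays open whether a methoxy group, an amine or a carboxylic acid on this ring would raise the number rather than lower it.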